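This account rests on a few compounds, and the source may have more. Where it says the series, first, only, none or still open, it means among the compounds named here.

In an ADME assay on MDBK cells (Bos taurus) for cytotoxicity, read by MTT assay, with a stated time of 96 h (a lower number here means that less compound is tolerated, a higher number that more compound is tolerated), compound 2 `O=C(CN1CCCCC1)Nc1ccc(-c2nc3cc(Cl)c(Cl)cc3[nH]2)cc1` gives 45000 nM, the second highest of the three numbers: compound 1 `Cn1c(-c2ccc(NC(=O)CN3CCCCC3)cc2)nc2cc(C(F)(F)F)ccc21` gives 100000 nM, and compound 3 `Nc1ccc(-c2nc3cc(Cl)c(Cl)cc3[nH]2)cc1` gives 7500 nM. Among the measured compounds shown here, the only step recorded within this set, a 6.0-fold lower number from compound 2 to compound 3 (0.78 log units; beyond the scatter), concerns hydrogen in place of the whole acyl group on the aromatic nitrogen, a different change from the one considered here. Compound 4 `CN1CCN(CC(=O)Nc2ccc(-c3nc4cc(Cl)c(Cl)cc4[nH]3)cc2)CC1` differs from compound 2 by 4-methylpiperazin-1-yl in place of piperidin-1-yl on a saturated chain carbon bound to a carbonyl carbon. For the measured compounds named here, no measured pair shows this exchange, so nothing sets its size, and a step in this assay of no more than the scatter is expected, in either direction. Compound 4 is therefore estimated at 50000 nM, with a range from 20000 nM to 100000 nM. The expected step of a 1.1-fold higher number from compound 2 to compound 4 (0.05 log units; within the scatter) stays within the scatter.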

Compound 4, half-maximal cytotoxic concentration: 90000 nM
For compound 4 the middle estimate is 1.8-fold (0.26 log units) below the measured one, and the stated range covers the measured number.
By their numbers in this assay, from the lowest: compound 3; then compounds 2, 4 and 1 (each within the scatter of the next, the first and the last beyond it).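

Among the compounds shown here, this is the first measured exchange at this place, on a saturated chain carbon bound to a carbonyl carbon: in this assay, the change from piperidin-1-yl to 4-methylpiperazin-1-yl gives a 2.0-fold higher number from compound 2 to compound 4 (0.30 log units; within the scatter). The earlier step removed the whole acyl group, whereas this one keeps the acyl group and shows that the second ring nitrogen and its methyl leave the number within the scatter. No available evidence bears on a cause for this result.

Morpholin-4-yl or an open-chain dimethylamino group at this place remains open. So does whether the same exchange gives a similar step on the core of compound 1.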